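Triazole for Hydroxyl on the Side Chain of Compound 3

A few compounds are considered here, and "the series" means these few. Any claim that something is new, unique, unknown or untested is made for them only; others in the source may bear on it.

Compound 1 `CNC(=O)C[C@@H]1C[C@@H](c2ccc(Cl)c(Cl)c2)[C@H](NC(=O)c2cc(-c3c(Cl)cnn3C)c(Cl)o2)CN1` gives 2.64 nM in an assay for inhibition of RAC-alpha serine/threonine-protein kinase (Homo sapiens), read by HTRF, with a stated time of 1 h; a lower number here means a stronger inhibitor, a higher number a weaker inhibitor.
Compound 2 `Cn1ncc(Cl)c1-c1cc(C(=O)N[C@@H]2CN[C@H](CCN3CCC(O)CC3)C[C@H]2c2ccc(Cl)c(Cl)c2)oc1Cl` gives 5.99 nM.
Compound 3 `Cn1ncc(Cl)c1-c1cc(C(=O)N[C@@H]2CN[C@H](CCCO)C[C@H]2c2ccc(Cl)c(Cl)c2)oc1Cl` gives 2.56 nM.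

Compound 3 has the lowest number of the three, but its distance from compound 1 is within the scatter, as a 1.0-fold lower number from compound 1 to compound 3 (0.01 log units; within the scatter) shows; only compound 2 stands apart, by a 2.3-fold lower number from compound 2 to compound 3 (0.37 log units; beyond the scatter).

Compound 4 `Cn1ncc(Cl)c1-c1cc(C(=O)N[C@@H]2CN[C@H](CCn3cncn3)C[C@H]2c2ccc(Cl)c(Cl)c2)oc1Cl` differs from compound 3 by 1H-1,2,4-triazol-1-yl in place of hydroxymethyl on a saturated chain carbon, two bonds along the chain from a saturated ring carbon. For the measured compounds named here, two measured steps bear on this position. The exchange of one side-chain group for another cost nothing in a 1.0-fold lower number from compound 1 to compound 3 (0.01 log units; within the scatter), while the ring-bearing group of compound 2 gave a 2.3-fold higher number from compound 1 to compound 2 (0.36 log units; beyond the scatter), a modest rise. Compound 4 also carries a ring there, so a small rise at most is expected: a 1.6-fold higher number from compound 3 to compound 4 (0.19 log units; within the scatter). Compound 4 is therefore estimated at 4 nM, between 1.5 nM and 12 nM.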

Compound 4, half-maximal inhibitory concentration: 4.47 nM
Beside the measured number, compound 4's estimate is 1.1-fold (0.05 log units) below it; measured number inside the range.
By their numbers in this assay, from the lowest: compounds 3, 1, 4 and 2 (each within the scatter of the next, the first and the last beyond it).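

In this assay, the step from hydroxymethyl to 1H-1,2,4-triazol-1-yl stays within the scatter (a 1.7-fold higher number from compound 3 to compound 4 (0.24 log units; within the scatter)), so this position takes a five-membered aromatic ring with 0 hydrogen-bond donors without a change that can be read. Compound 4 also cannot be told apart from either other side chain (a 1.3-fold lower number from compound 2 to compound 4 (0.13 log units; within the scatter); a 1.7-fold higher number from compound 1 to compound 4 (0.23 log units; within the scatter)). No evidence is available to explain why these groups read alike.

The compounds shown leave open how a primary amine, a carboxylic acid or a longer chain ending in the triazole would read at this position.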